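Adding a second methoxy to compound 2

The source may hold more compounds than are shown below. What is called first, only, known or untested is meant among the compounds shown, and "the series" means these compounds.

Measured in an ADME assay on Vero cells (Chlorocebus sabaeus) for cytotoxicity, read by MTT assay, with a stated time of 96 h; a higher number here means that more compound is tolerated, a lower number that less compound is tolerated:
- compound 1 `C/C(=N\NC(N)=O)c1ccc2c(c1)nc(-c1ccccc1)n2C1CCCCC1`: > 100000 nM
- compound 2 `COc1ccc(-c2nc3cc(/C(C)=N/NC(N)=O)ccc3n2C2CCCCC2)cc1`: "not determined" (no result reported)

Not yet measured: compound 3 `COc1ccc(-c2nc3cc(/C(C)=N/NC(N)=O)ccc3n2C2CCCCC2)c(OC)c1`

Compound 1 gives > 100000 nM in this assay and this entry is a limit, not a number. Among the compounds with values here, compound 1 thus supplies the only reading, (the limit of > 100000 nM in this assay, at which 1 of the 2 values shown sits). For compound 2 the entry reads "not determined" (no result reported) and it therefore has no single number of its own.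

The change under study is methoxy in place of hydrogen on an aromatic carbon, which takes 4-methoxyphenyl to 2,4-dimethoxyphenyl: methoxy in place of hydrogen on an aromatic carbon, ortho to a large group and meta to a methoxy group. Within the data shown here, no measured step shows what such a change does in this assay. Among the measured compounds shown here, the only guide is compound 1 with its limit of > 100000 nM as reported. No shift beyond the usual scatter is expected from that reading, and no direction is favoured. Another report as a limit is expected to be likely. In this assay the estimate for compound 3 is an expected 90000 nM, within a range of 30000 nM to 150000 nM.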

Compound 3, half-maximal cytotoxic concentration: 20000 nM
Compound 3: middle estimate off by 4.5-fold (0.65 log units), on the high side; measured number outside the range, below it.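

In this assay, within the data shown here, compound 3 gives the first real number of the series, 20000 nM, and so shows that this aryl position is not silent in the assay. Replacing phenyl with 2,4-dimethoxyphenyl comes with an at least 5.0-fold lower number from compound 1 to compound 3 (0.69 log units; beyond the scatter), which is a change beyond the scatter and the first sign that substitution on this aromatic ring can lower the tolerated concentration. The reading for compound 1 is a limit and not a number: the limit of > 100000 nM in this assay, at which 1 of the 3 values shown sits.

Going by these compounds, with no result reported for compound 2, the step from 4-methoxyphenyl to 2,4-dimethoxyphenyl cannot be read, so the part played by the added methoxy alone, as distinct from the methoxy already present in compound 2, remains open. Also open, on these data alone, is whether an amine, a hydroxyl or a fluorine on the same aromatic carbon, ortho to a large group and meta to a methoxy group, would give a number close to that of compound 3 or a limit like that of compound 1.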